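Extending the Ester End of a Nitrophenyl Amide Series

The compounds below may be only part of what the source reports. "The series", "measured", "known", "first", "only" and "open" are said of these compounds alone.

Measured so far:
Compound 1 `COc1ccc(C(=O)OC2(C(=O)Nc3ccc([N+](=O)[O-])cc3)CCCCC2)cc1`: 38.8 nM
Compound 2 `O=C(OC1(C(=O)Nc2ccc([N+](=O)[O-])cc2)CCCCC1)c1ccc(Br)cc1`: 236 nM
Compound 3 `O=COC1(C(=O)Nc2ccc([N+](=O)[O-])cc2)CCCCC1`: 33.8 nM

These three compounds share a core and differ only in the group attached to the ester carbonyl carbon. In a functional assay on NFS-60 cells (Mus musculus) for inhibition, read by MTT assay, with a stated time of 72 h (a lower number here means a stronger inhibitor, a higher number a weaker inhibitor), compound 3, which carries a plain hydrogen at that position, gives the lowest number of the three, though its gap to compound 1 lies within the scatter, so the two cannot be ranked against each other. Compound 2 stands clearly apart: the step of a 7.0-fold lower number from compound 2 to compound 3 (0.84 log units; beyond the scatter) is beyond the scatter, while a 1.1-fold lower number from compound 1 to compound 3 (0.06 log units; within the scatter) is not.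

Compound 4 `O=C(OC1(C(=O)Nc2ccc([N+](=O)[O-])cc2)CCCCC1)C(O)c1ccccc1` is the next candidate. Its change from compound 3 is hydroxy(phenyl)methyl in place of hydrogen on a carbonyl carbon. The two measured steps that bear on this position are the two just named: replacing a hydrogen with one aryl group left the number essentially unchanged, while another aryl group raised it modestly. A group of comparable size is therefore expected to give at most a modest rise, a 2.1-fold higher number from compound 3 to compound 4 (0.32 log units; beyond the scatter), and the estimated value for compound 4 in this assay is 70 nM, with a range from 25 nM to 250 nM.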

Compound 4, half-maximal inhibitory concentration: 7.8 nM
For compound 4 the middle estimate is 9.0-fold (0.95 log units) above the measured one; measured number below the stated range.
By their numbers in this assay, from the lowest: compound 4; then compounds 3 and 1 (each within the scatter of the next); then compound 2.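

In this assay hydroxy(phenyl)methyl gives a 4.3-fold lower number from compound 3 to compound 4 (0.64 log units; beyond the scatter) and so beats plain hydrogen on this carbonyl carbon, which neither 4-methoxyphenyl nor 4-bromophenyl did. The same group also gives a 5.0-fold lower number from compound 1 to compound 4 (0.70 log units; beyond the scatter) and a 30-fold lower number from compound 2 to compound 4 (1.48 log units; beyond the scatter) when it replaces those aryl groups, so a group carrying a phenyl ring can sit here with a clear gain, and the form of that group matters a great deal. No measurement on hand explains this gain.

The compounds shown leave open whether the hydroxy or the phenyl ring accounts for the gain, a question that benzyl or hydroxymethyl at this position could address. From the compounds shown here alone, how an amine in place of the hydroxy would compare also remains open.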